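Cytotoxicity notes: isobutyl replaces 2-methylphenyl in compound 1

The compounds below may be only part of what the source reports. "The series", "measured", "known", "first", "only" and "open" are said of these compounds alone.

Compound 1 `Cc1ccccc1Cn1ccc2nc(-c3ccccc3)nc-2c1` has been run in an ADME assay on MDBK cells (Bos taurus) for cytotoxicity; on this read-out lower numbers stand for higher toxicity in this test and higher numbers for lower toxicity in this test. In this assay compound 1 gives > 100000 nM, which is a limit of the assay and not a number. Compound 3 `CCn1ccc2nc(-c3ccccc3)nc-2c1` carries ethyl on the aromatic nitrogen. In this assay compound 3 gives > 100000 nM, again a limit. Compound 2 `c1ccc(-c2nc3cc[nH]cc-3n2)cc1` carries hydrogen on the aromatic nitrogen. In this assay compound 2 gives > 100000 nM, also a limit. Among the measured compounds shown here, the only steps measured around compound 1 are a step that the two limits leave unreadable from compound 1 to compound 3 and a step that the two limits leave unreadable from compound 2 to compound 3; neither has a readable size, since (the limit of > 100000 nM in this assay, at which 3 of the 3 values shown sit).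

Compound 4 `CC(C)CCn1ccc2nc(-c3ccccc3)nc-2c1` is not yet measured. Its change from compound 1 is isobutyl in place of 2-methylphenyl on a saturated chain carbon bound to an aromatic nitrogen. For the measured compounds named here, the step from compound 1 to compound 3 is the nearest precedent, as it also swaps the group on the saturated chain carbon bound to an aromatic nitrogen, but it too is unreadable. Because the limit of > 100000 nM in this assay, at which 3 of the 3 values shown sit, holds for every measured member of the series, compound 4 is expected to sit at the same limit, and no step beyond the scatter is expected. Compound 4 is therefore estimated at 150000 nM, with a range from 50000 nM to 400000 nM. The expected step that the limit leaves unreadable from compound 1 to compound 4 amounts to no change beyond the scatter.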

Compound 4, half-maximal cytotoxic concentration: > 100000 nM
Compound 4: only a limit was reported (the forecaster's own chance of this, stated with the estimate: 85%); the middle value does not contradict the limit.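

In this assay compound 4 shows only a limit and not a number, so its steps from compound 1, compound 2 and compound 3 cannot be read, and no new step emerges: the limit of > 100000 nM in this assay, at which 4 of the 4 values shown sit.

The compounds shown leave open whether any group on the aromatic nitrogen changes this read-out at all.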